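Swapping the benzyl halogens in a weakly cytotoxic series

The source may report more compounds than this note shows. Statements on the series, on what has been measured and on what is new or still open speak of the compounds shown alone.

Of the compounds shown here, three sharing one core have been measured in a functional assay on MDA-MB-231 cells (Homo sapiens) for inhibition, read by sulforhodamine B assay, with a stated time of 48 h; on this read-out lower numbers stand for higher toxicity in this test and higher numbers for lower toxicity in this test. Compound 1, `Nc1cc(N)c2nc(-c3ccccc3)c(Oc3ccc(Cl)c(Cl)c3)nc2c1`, gives 66100 nM in this assay. Compound 2, `Nc1cc(N)c2nc(-c3ccccc3)c(NCc3ccc(Cl)c(Cl)c3)nc2c1`, reaches only a limit of the assay in this assay, < 100000 nM. Compound 3, `CCOC(=O)[C@H](CCC(=O)O)NC(=O)c1ccc(Sc2nc3cc(N)cc(N)c3nc2-c2ccccc2)cc1`, likewise reaches only a limit in this assay, < 100000 nM. So compound 2 stands at the limit rather than at a number, and it shares that position with one other compound, as the limit of < 100000 nM in this assay, at which 2 of the 3 values shown sit, records; no measured pair differing in a single place is available to show how a change of this kind shifts the read-out.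

The unmeasured compound 4, `Nc1cc(N)c2nc(-c3ccccc3)c(NCc3ccc(F)cc3)nc2c1`, differs from compound 2 by 4-fluorophenyl in place of 3,4-dichlorophenyl on a saturated chain carbon bound to a nitrogen on an aromatic ring. Within the data shown here, with no measured step to lean on, and with compound 2 itself known only as a limit, the expectation is that compound 4 stays in the same weak range, and the expected step from compound 2 to compound 4 is a step that the limit leaves unreadable from compound 2 to compound 4, which is no more than the usual scatter would allow. Compound 4 is therefore estimated to show 80000 nM in this assay, within a range from 30000 nM to 200000 nM, with a real chance that only a limit is reported again.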

Compound 4, concentration lethal to 50% of the cells: 19500 nM
Compound 4: the middle estimate sits 4.1-fold (0.61 log units) above what was measured; measured number below the stated range.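

In this assay compound 4 gives 19500 nM, which shows that a benzyl group joined through nitrogen at this position of the shared core can give a measurable number. Putting (4-fluorobenzyl)amino in place of 3,4-dichlorophenoxy on an aromatic carbon gives a 3.4-fold lower number from compound 1 to compound 4 (0.53 log units; beyond the scatter), a modest move towards higher toxicity in this test, though this single step changes the linking atom and the halogens together. Compound 2 is recorded only as a limit, so the step that starts from it, the direct swap of 3,4-dichlorobenzyl for 4-fluorobenzyl, cannot be read: the limit of < 100000 nM in this assay, at which 2 of the 4 values shown sit.

The compounds shown therefore do not separate the effect of the halogens from that of the link to the core, a question that a fluorophenoxy group on the same carbon could help to settle. They also leave open how an unsubstituted benzyl group, a methoxybenzyl group or a longer chain on that nitrogen would read in this assay.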